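Replacing 2,4-difluorophenyl with 4-methoxyphenyl on a shared core

The source may hold more compounds than are shown below. What is called first, only, known or untested is meant among the compounds shown, and "the series" means these compounds.

In a functional assay on K562 cells (Homo sapiens) for antiproliferative activity, with a stated time of 72 h (a lower number here means a stronger inhibitor, a higher number a weaker inhibitor), compound 1 `Nc1ncnn2c([C@@H]3O[C@H](CO)[C@@H](O)[C@H]3O)cc(-c3ccccc3)c12` gives > 100000 nM, which is a limit of the assay and not a number. Going by the values given here, compound 2 `Nc1ncnn2c([C@@H]3O[C@H](CO)[C@@H](O)[C@H]3O)cc(-c3ccc(F)cc3F)c12` gives 69700 nM, the only true number so far. Among the compounds with values here, the one measured step is an at least 1.4-fold lower number from compound 1 to compound 2 (0.15 log units; that floor lies within the scatter), and its full size stays open because of the limit of > 100000 nM in this assay, at which 1 of the 2 values shown sits. Compound 3 `COc1ccc(-c2cc([C@@H]3O[C@H](CO)[C@@H](O)[C@H]3O)n3ncnc(N)c23)cc1` differs from compound 2 in one place: 4-methoxyphenyl in place of 2,4-difluorophenyl on an aromatic carbon. Here 4-methoxyphenyl stands in place of 2,4-difluorophenyl on an aromatic carbon, the same carbon that changed in the measured step. Within the data shown here, with an at least 1.4-fold lower number from compound 1 to compound 2 (0.15 log units; that floor lies within the scatter) as the only guide, and its floor within the scatter, no step beyond the scatter is expected in this assay. The estimated change is a 1.0-fold higher number from compound 2 to compound 3 (0.00 log units; within the scatter). For compound 3 the expected value is 70000 nM, with an estimated range of 25000 nM to 150000 nM.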

Compound 3, half-maximal inhibitory concentration: 76400 nM
Compound 3: middle estimate off by 1.1-fold (0.04 log units), on the low side; the range from low to high includes it.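

In this assay, the step at this aromatic carbon is a 1.1-fold higher number from compound 2 to compound 3 (0.04 log units; within the scatter), so compound 2 and compound 3 cannot be told apart, even though fluorine leaves and oxygen enters with the change of group. From the compounds shown here alone, the step from the plain phenyl is an at least 1.3-fold lower number from compound 1 to compound 3 (0.11 log units; that floor lies within the scatter), and compound 1 stands at a limit and not a number, so the full size of this step stays open because of that limit: the limit of > 100000 nM in this assay, at which 1 of the 3 values shown sits. Going by these compounds alone, the only true numbers at this position now come from two differently substituted phenyl groups, and they lie within the scatter of each other.

The compounds shown leave open whether a group other than a phenyl ring, such as an amine, a carboxylic acid or a longer chain, would give a step beyond the scatter at this carbon. They also leave open whether a chlorine or a nitrile on the phenyl ring would do so.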